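The compounds below may be only part of what the source reports. "The series", "measured", "known", "first", "only" and "open" are said of these compounds alone.

Measured compounds in an assay on membranes from brain for binding affinity to Lysophosphatidylserine lipase ABHD12 (Mus musculus), read by fluorescence, with a stated time of 20 min; on this read-out lower numbers stand for stronger inhibition and higher numbers for weaker inhibition:
compound 1 `FC(F)(F)Oc1ccccc1Oc1ccnc(N2CCC(NC(=S)Nc3cccnc3)CC2)c1Cl`: 96 nM
compound 2 `FC(F)(F)Oc1ccc(Oc2ccnc(N3CCC(NC(=S)Nc4cccnc4)CC3)c2Cl)c(Cl)c1`: 11 nM

Compound 2 holds the lowest number of the two measured compounds; its nearest neighbour is compound 1, separated by the step of an 8.7-fold lower number from compound 1 to compound 2 (0.94 log units; beyond the scatter). Within the data shown here, that step is the only measured change on the oxygen on the aromatic ring: it replaced the group of compound 1 with one that carries an additional chlorine and places the trifluoromethoxy differently, and it was beyond the scatter.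

Compound 3 `FC(F)(F)Oc1ccc(Oc2ccnc(N3CCC(NC(=S)Nc4cccnc4)CC3)c2Cl)cc1Cl` differs from compound 2 by a group of 12 heavy atoms (7 carbon, 1 oxygen, 3 fluorine, 1 chlorine; one six-membered aromatic ring of carbon only) in place of a group of 12 heavy atoms (7 carbon, 1 oxygen, 3 fluorine, 1 chlorine; one six-membered aromatic ring of carbon only), on an oxygen on an aromatic ring. The two groups have the same atoms and the same substituents; only the arrangement on the ring changes. Among the measured compounds shown here, no measured pair tests such a rearrangement within a group of identical composition, so the step from compound 1 to compound 2 bears on it only loosely, as a sign that this position of the molecule can shift the read-out. With nothing to point in either direction, the step is expected to stay within the scatter, a 1.4-fold higher number from compound 2 to compound 3 (0.13 log units; within the scatter), with no direction favoured. Compound 3 is therefore estimated at 15 nM, with a range from 5 nM to 45 nM.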

Compound 3, half-maximal inhibitory concentration: 33 nM
Compound 3: middle estimate off by 2.2-fold (0.34 log units), on the low side, and the stated range covers the measured number.
By their numbers in this assay, from the lowest: compound 2; then compound 3; then compound 1.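

Within this assay, moving the same substituents around the ring on this oxygen is not a neutral change: a 3.0-fold higher number from compound 2 to compound 3 (0.48 log units; beyond the scatter), so the arrangement alone shifts the read-out, with the group's atoms and its counted features unchanged. The 3-chloro-4-(trifluoromethoxy)phenyl group still reads stronger than 2-(trifluoromethoxy)phenyl, with a 2.9-fold lower number from compound 1 to compound 3 (0.46 log units; beyond the scatter), which gives a second chlorine-bearing arrangement on the lower side of the chlorine-free group, though a smaller gain than the arrangement in compound 2 shows against that same group. Nothing available accounts for the effect of the arrangement on the read-out.

The chlorine and the placement of the trifluoromethoxy change together in these steps, so their separate shares remain unassigned; a 4-(trifluoromethoxy)phenyl without chlorine, or a fluorine or methyl in place of the chlorine, would bear directly on that question. From the compounds shown here alone, it also remains open whether this order of the three groups carries over to a different substituent on the shared core, such as a carboxylic acid or an amine, since all three values come from a single core and this assay.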